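This account rests on a few compounds, and the source may have more. Where it says the series, first, only, none or still open, it means among the compounds named here.

For the measured compounds named here, in a functional assay on A549 cells (Homo sapiens) for inhibition, read by MTT assay, with a stated time of 48 h (a lower number here means a stronger inhibitor, a higher number a weaker inhibitor), three compounds built on a shared core have numbers so far. Compound 1 `COc1ccc(-c2nc3ccccn3c2Sc2ccccc2)cc1` gives 58400 nM, the highest of the three, which makes it the weakest inhibitor measured. Compound 2 `c1ccc(Sc2c(-c3cccc4ccccc34)nc3ccccn23)cc1` gives 17900 nM and compound 3 `Cc1ccc(-c2nc3ccc(C)cn3c2Sc2ccccc2)cc1` gives 23800 nM. Each of these two lies below compound 1 by more than the usual scatter of repeated measurements, while the two sit close to each other.

The next compound to consider is compound 4 `Clc1ccc(-c2nc3ccccn3c2Sc2ccccc2)cc1`. It keeps the core of compound 1 and changes one group: 4-methoxyphenyl becomes 4-chlorophenyl, with chloro in place of methoxy on an aromatic carbon, para to a large group (chloro in place of methoxy on an aromatic carbon).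

The measured compounds offer no direct comparison for this swap, so the expectation rests on weak ground. Compound 1, at 58400 nM, stands at the top of the small range seen so far, and a new close relative seems more likely to fall towards the other two than to climb further. The expected step is therefore downward but small, a 1.8-fold lower number from compound 1 to compound 4 (0.26 log units; within the scatter), and would stay within the scatter. For compound 4 the estimated value is 32000 nM, with an expected range of 13000 nM to 75000 nM.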

Compound 4, half-maximal inhibitory concentration: 22000 nM
The estimate for compound 4 lay 1.5-fold (0.16 log units) above the measured number; measured number inside the range.
By their numbers in this assay, from the lowest: compounds 2, 4 and 3 (each within the scatter of the next); then compound 1.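

For the compounds shown here, replacing 4-methoxyphenyl with 4-chlorophenyl gives a 2.7-fold lower number from compound 1 to compound 4 (0.42 log units; beyond the scatter) in this assay, the first comparison here in which only one place changes. Going by these compounds alone, although modest, this step shows that the group on this aromatic carbon, para to a large group, can shift the number by more than the scatter; the earlier compounds could not show this, as no two of them differed in one place alone. The data offer no measurement that explains the shift, and the change from methoxy to chloro cannot be tied to any particular property of either group.

Within the data shown here, with only two groups compared at this position, a single step gives no trend, and it remains open how an amine, a carboxylic acid, a fluoro group or a longer chain such as butoxy would read in the same place. As far as these compounds go, it is also open whether chloro in place of methoxy would give a similar step on a core carrying other changes, or whether moving the chloro to another carbon of this ring would preserve it.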